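Methoxy in place of methyl on compound 2

The compounds below may be only part of what the source reports. "The series", "measured", "known", "first", "only" and "open" are said of these compounds alone.

Compound 1 `Cc1ccnc(C)c1NC(=O)[C@@H]1CCCN1S(=O)(=O)c1cccc2cccnc12`: > 50000 nM (a limit)
Compound 2 `Cc1ccc(C)c(NC(=O)[C@@H]2CCCN2S(=O)(=O)c2cccc3cccnc23)c1`: 30900 nM

For the measured compounds named here, in an ADME assay on HEp-2 cells (Homo sapiens) for cytotoxicity (on this read-out lower numbers stand for higher toxicity in this test and higher numbers for lower toxicity in this test), compound 2 gives 30900 nM, the only true number so far. Compound 1 reports only a limit, > 50000 nM. Compound 3 `COc1ccc(C)cc1NC(=O)[C@@H]1CCCN1S(=O)(=O)c1cccc2cccnc12` carries methoxy in place of methyl on an aromatic carbon, ortho to a large group (methoxy in place of methyl on an aromatic carbon). Going by the values given here, the one measured step, an at least 1.6-fold lower number from compound 1 to compound 2 (0.20 log units; that floor lies within the scatter), lies within the scatter and concerns a different change, so it offers no size for this one. With compound 2 at 30900 nM as the anchor, no shift beyond the scatter is expected. The estimated step of a 1.1-fold higher number from compound 2 to compound 3 (0.05 log units; within the scatter) reflects this. Compound 3 is expected at 35000 nM, with an estimated range of 16000 nM to 50000 nM.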

Compound 3, half-maximal cytotoxic concentration: > 50000 nM
Compound 3: a limit, no number (the forecaster's own chance of this, stated with the estimate: 35%); middle value at least 1.4-fold (0.15 log units) away from the limit.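

From the compounds shown here alone, at this position, ortho to a large group, methoxy in place of methyl in this assay gives an at least 1.6-fold higher number from compound 2 to compound 3 (0.20 log units; that floor lies within the scatter), so this change does not bring the number down, though its true size stays unknown. Compound 3 reports only a limit, as compound 1 does, so the step between those two cannot be read. Compound 2 alone carries a true number, and the others sit at the ceiling of the read-out: the limit of > 50000 nM in this assay, at which 2 of the 3 values shown sit. Going by these compounds, whether an amine or a carboxylic acid at this position would bring the number down remains open.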